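From phenyl to 2,4-dichlorophenyl on compound 2

The source may report more compounds than this note shows. Statements on the series, on what has been measured and on what is new or still open speak of the compounds shown alone.

In an ADME assay on MT4 cells (Homo sapiens) for cytotoxicity, read by MTT assay (a lower number here means that less compound is tolerated, a higher number that more compound is tolerated), compound 2 `O=C(CSc1nncnc1-c1ccccc1Cl)Nc1ccccc1` gives 127000 nM, the higher of the two numbers available. For the measured compounds named here, the only other measured compound, compound 1 `O=C(CSc1nncnc1-c1ccccc1Cl)c1ccc(Cl)c(Cl)c1`, gives 33000 nM. Compound 3 `O=C(CSc1nncnc1-c1ccccc1Cl)Nc1ccc(Cl)cc1Cl` differs from compound 2 by one change, 2,4-dichlorophenyl in place of phenyl on an amide-type nitrogen. Going by the values given here, the one measured step that bears on it, a 3.8-fold higher number from compound 1 to compound 2 (0.59 log units; beyond the scatter), is modest and has anilino in place of 3,4-dichlorophenyl on a carbonyl carbon, so a lower number of similar size is expected for compound 3. This rests on a single indirect comparison, so the expectation stays loose. The expected change in this assay is a 2.8-fold lower number from compound 2 to compound 3 (0.45 log units; beyond the scatter). The estimate for compound 3 is 45000 nM, with an expected range of 15000 nM to 110000 nM.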

Compound 3, half-maximal cytotoxic concentration: 51000 nM
Beside the measured number, compound 3's estimate is 1.1-fold (0.05 log units) below it, and the stated range covers the measured number.
By their numbers in this assay, from the lowest: compounds 1 and 3 (each within the scatter of the next); then compound 2.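

In this assay, for the compounds shown here, the change to 2,4-dichlorophenyl on the amide-type nitrogen gives a 2.5-fold lower number from compound 2 to compound 3 (0.40 log units; beyond the scatter) and so offers the first reading of a substitution on this phenyl group with the carbonyl carbon and the nitrogen left in place. The earlier step had exchanged the anilino group for 3,4-dichlorophenyl on the carbonyl carbon, which removed that nitrogen as well, whereas here the position alone shows that adding two chlorine atoms to the phenyl group leaves a modest drop in the tolerated concentration. No measurement at hand gives a reason for this step.

Going by these compounds, whether a single chlorine would produce a step of this size remains open. So does the question of how a methoxy group, an amine or a carboxylic acid on this phenyl group would move the number.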